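An Acetoxy Group Enters the Side Chain of Compound 1

The source may hold more compounds than are shown below. What is called first, only, known or untested is meant among the compounds shown, and "the series" means these compounds.

Compound 1 `COc1ccc(O)c2c1C(=O)C=C(CCC=C(C)C)C2=O` was tested in a functional assay on MCF7 cells (Homo sapiens) for cytotoxicity, read by MTT assay, with a stated time of 48 h (a higher number here means a weaker inhibitor, a lower number a stronger inhibitor), where compound 1 gives 16000 nM. Its companion compound 2 `COc1ccc(O)c2c1C(=O)C(CCC=C(C)C)=CC2=O` gives 11900 nM in this assay, a number that lies within the scatter of compound 1, so the two cannot be told apart. Compound 3 `COc1ccc(O)c2c1C(=O)C=C([C@H](CC=C(C)C)OC(C)=O)C2=O` has not yet been measured. It differs from compound 1 by acetoxy in place of hydrogen on a saturated chain carbon bound to a double-bonded ring carbon and a saturated chain carbon. Going by the values given here, no measured pair shows this change, so the step expected in this assay, a 1.6-fold lower number from compound 1 to compound 3 (0.20 log units; within the scatter), is small and need not exceed the scatter. Compound 3 is therefore estimated at 10000 nM, with a range from 4000 nM to 30000 nM.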

Compound 3, half-maximal inhibitory concentration: 14100 nM
Compound 3: the middle estimate sits 1.4-fold (0.15 log units) below what was measured, within the range that was stated.
By their numbers in this assay, from the lowest: compounds 2, 3 and 1 (each within the scatter of the next).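

In this assay, acetoxy in place of hydrogen on this saturated chain carbon gives a 1.1-fold lower number from compound 1 to compound 3 (0.05 log units; within the scatter) and so does not separate the two compounds. This first measured pair at the position shows that the side chain of compound 1 can carry acetoxy, with its 4 heavy atoms, without a step beyond the scatter. Nothing measured here offers an explanation for this result. As far as these compounds go, whether a hydroxyl or an amine on this carbon would give a step beyond the scatter remains open. So does the effect of acetoxy on the side chain of compound 2.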